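From pyrrolidin-1-yl to diethylamino on the side chain

The source may hold more compounds than are shown below. What is called first, only, known or untested is meant among the compounds shown, and "the series" means these compounds.

Compound 2 `O=c1cc(-c2ccccc2)oc2cc(OCc3ccccc3)c(OCCCCN3CCCC3)c(O)c12` gives 800 nM in a functional assay on A549 cells (Homo sapiens) for antiproliferative activity, read by MTT assay, with a stated time of 48 h (on this read-out higher numbers stand for weaker inhibition and lower numbers for stronger inhibition), the lowest of the two numbers measured; compound 1 `O=c1cc(-c2ccccc2)oc2cc(OCc3ccccc3)c(OCCCN3CCCCC3)c(O)c12` gives 3100 nM. Among the compounds with values here, the only measured step, a 3.9-fold lower number from compound 1 to compound 2 (0.59 log units; beyond the scatter), exchanges one ring-containing group for another, so it bears only loosely on the change now in question. Compound 3 `CCN(CC)CCCCOc1c(OCc2ccccc2)cc2oc(-c3ccccc3)cc(=O)c2c1O` carries diethylamino in place of pyrrolidin-1-yl on a saturated chain carbon, four bonds along the chain from an oxygen on an aromatic ring. Within the data shown here, since no measured step exchanges a ring-containing group for one with no ring, a step of about a 1.1-fold higher number from compound 2 to compound 3 (0.05 log units; within the scatter) is expected, which stays within the scatter. Compound 3 is therefore estimated at 900 nM, with a range from 300 nM to 2700 nM.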

Compound 3, half-maximal inhibitory concentration: 1800 nM
Compound 3: the middle estimate sits 2.0-fold (0.30 log units) below what was measured; the measured number falls inside the stated range.
By their numbers in this assay, from the lowest: compound 2; then compounds 3 and 1 (each within the scatter of the next).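

In this assay the pyrrolidin-1-yl ring gives way to diethylamino, with the same count of heavy atoms, and the step (a 2.3-fold higher number from compound 2 to compound 3 (0.35 log units; beyond the scatter)) shows that removing the ring at this place on the chain changes the number. Set against the piperidin-1-yl compound, the step (a 1.7-fold lower number from compound 1 to compound 3 (0.24 log units; within the scatter)) leaves those two unranked. Nothing measured here explains the difference between the ring and open-chain amines.

On these data alone, whether pyrrolidin-1-yl keeps its edge over diethylamino on a shorter chain stays open. So does how morpholin-4-yl or dimethylamino would compare at the same place.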